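This account rests on a few compounds, and the source may have more. Where it says the series, first, only, none or still open, it means among the compounds named here.

Measured compounds:
compound 1, `O=C(Nc1ccncc1)Nc1ccccc1OCc1ccccc1`: > 300 mg/kg
compound 2, `O=C(Nc1ccncc1)Nc1cccc([N+](=O)[O-])c1`: > 300 mg/kg
compound 3, `O=C(Nc1ccncc1)Nc1ccc([N+](=O)[O-])cc1`: > 300 mg/kg

In a functional assay on the whole organism with Mus musculus as the target, in the maximal electroshock model, with a stated time of 30 min (on this read-out lower numbers stand for an effect already at smaller amounts and higher numbers for an effect only at larger amounts of compound), compound 1 reaches only the limit of the assay, > 300 mg/kg. Compound 2 likewise gives only a limit, > 300 mg/kg. Compound 3 also stands at a limit, > 300 mg/kg. Where compound 3 stands is therefore simply (the limit of > 300 mg/kg in this assay, at which 3 of the 3 values shown sit); none of the three gives a numbered dose, and no compound can be set above or below another.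

Compound 4, `O=C(Nc1ccncc1)Nc1ccc(Oc2ccccc2)cc1`, is not yet measured in this assay. Against compound 3 it carries phenoxy in place of nitro on an aromatic carbon. Going by the values given here, no step between measured compounds exists, so nothing shows how far such a change moves the dose. The whole series sits at the limit, and a reading that reaches a number is not expected with any confidence. Compound 4 is expected near 250 mg/kg, with a range from 100 mg/kg to 600 mg/kg. The step this estimate means, an at least 1.2-fold lower number from compound 3 to compound 4 (0.07 log units; that floor lies within the scatter), is expected to be small, with a fair chance that only a limit is reported again.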

Compound 4, minimum effective dose: > 300 mg/kg
Compound 4: a limit, no number (the forecaster's own chance of this, stated with the estimate: 60%); middle value at least 1.2-fold (0.07 log units) away from the limit.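

No step can be read from compound 3 to compound 4: both give only a limit, and the series stays at a single reading: the limit of > 300 mg/kg in this assay, at which 4 of the 4 values shown sit. The compounds shown leave open at what dose any of them acts, and how the groups on the shared core rank.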